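The compounds below may be only part of what the source reports. "The series", "measured", "known", "first", "only" and "open" are said of these compounds alone.

Measured so far in a functional assay for antagonist activity at P2X purinoceptor 7 (Homo sapiens), read by FLIPR and calcium flux; on this read-out higher numbers stand for weaker inhibition and lower numbers for stronger inhibition:
compound 1 `Clc1cccc(-n2cnnc2NCc2cccnc2)c1Cl` gives 355 nM;
compound 2 `Clc1cccc(-n2cnnc2NCc2cccnc2N2CCCC2)c1Cl` gives 14.8 nM;
compound 3 `NC(=O)CN1CCCN(c2ncccc2CNc2nncn2-c2cccc(Cl)c2Cl)CC1` gives 32.4 nM.

Compound 3 stands second highest of the three numbers in this assay: its nearest neighbour is compound 2, whose number is the lower of the two, and its furthest is compound 1, whose number is the higher of the two; both gaps lie beyond the scatter.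

Compound 4 `CC(C)N1CCCN(c2ncccc2CNc2nncn2-c2cccc(Cl)c2Cl)CC1` differs from compound 3 by isopropyl in place of carbamoylmethyl on an amine nitrogen in a ring. Within the data shown here, the one measured step, a 24-fold lower number from compound 1 to compound 2 (1.38 log units; beyond the scatter), concerns another place, pyrrolidin-1-yl in place of hydrogen on an aromatic carbon, and does not bear on an exchange at the amine nitrogen in the seven-membered ring. Among the measured compounds shown here, no measured pair shows any change at that nitrogen, so the size of the step cannot be anchored on the numbers at hand. In this assay compound 4 is therefore expected to move no further than the scatter allows, the estimated step being a 1.2-fold lower number from compound 3 to compound 4 (0.06 log units; within the scatter). Compound 4 is expected at 28 nM, with a range from 9 nM to 90 nM.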

Compound 4, half-maximal inhibitory concentration: 67.6 nM
Estimate against measurement, compound 4: 2.4-fold (0.38 log units) below, and the stated range covers the measured number.
By their numbers in this assay, from the lowest: compound 2; then compound 3; then compound 4; then compound 1.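

In this assay the amine nitrogen of the seven-membered ring proves sensitive to its substituent: isopropyl in place of carbamoylmethyl gives a 2.1-fold higher number from compound 3 to compound 4 (0.32 log units; beyond the scatter), a modest step and the first one read at this position. The 4-isopropyl-1,4-diazepan-1-yl group keeps part of the gain over hydrogen, with a 5.3-fold lower number from compound 1 to compound 4 (0.72 log units; beyond the scatter), but falls short of pyrrolidin-1-yl, with a 4.6-fold higher number from compound 2 to compound 4 (0.66 log units; beyond the scatter). No evidence at hand explains these differences.

Two groups on this nitrogen do not show which part of the exchange carries the step, and a methyl group, a plain hydrogen or a longer chain ending in a carboxylic acid could fall on either side of compound 3. On these data alone, it also remains open whether a primary amide on a different chain length would match carbamoylmethyl.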